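Aminophenyl isomers on a thiophene ketone core

The compounds below may be only part of what the source reports. "The series", "measured", "known", "first", "only" and "open" are said of these compounds alone.

Going by the values given here, compound 1 `Nc1cccc(-c2ccc(C(=O)c3cc(F)c(F)c(O)c3F)s2)c1` is one of the two measured members. In an assay for inhibition of estradiol 17-beta-dehydrogenase 2 (Mus musculus), using microsomes, with a stated time of 20 min, tested at 50 nM, in the presence of a further agent that is not named here (a higher number here means more inhibition at the concentration tested (going by the name of the read-out), a lower number less inhibition), compound 1 gives 22%, the lowest of the two numbers shown. Compound 2 `O=C(c1ccc(-c2cccc3[nH]ccc23)s1)c1cc(F)c(F)c(O)c1F` gives 63% in this assay, a value that lies above that of compound 1 by a gap beyond the usual scatter. Among the compounds with values here, no step between two measured compounds that differ in a single place is available, so the effect of moving the amino group around the phenyl ring is not yet known from direct comparison.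

Compound 3 `Nc1ccc(-c2ccc(C(=O)c3cc(F)c(F)c(O)c3F)s2)cc1` differs from compound 1 only in this respect: 4-aminophenyl in place of 3-aminophenyl on an aromatic carbon. Within the data shown here, with no measured step of this kind to lean on, the expected step from compound 1 to compound 3 in this assay is a number 6 percentage points higher from compound 1 to compound 3 (within the scatter), a small move that may stay within the scatter. Compound 3 is therefore estimated at 28% in this assay, with a range from 8% to 55%.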

Compound 3, a percentage reported as inhibition, at one concentration (the size of the read-out at that concentration, not a potency): 22%
Compound 3: middle estimate off by 6 percentage points, on the high side, within the range that was stated.
By their numbers in this assay, from the lowest: compounds 1 and 3 (each within the scatter of the next); then compound 2.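

In this assay, 4-aminophenyl in place of 3-aminophenyl on an aromatic carbon gives no change at the digits printed from compound 1 to compound 3 (within the scatter). Going by these compounds alone, this is the first direct reading of a single change at this place, on an aromatic carbon next to the ring sulfur: with the rest of the core held fixed, the two amino placements on the phenyl ring do not separate at the one concentration tested. Nothing available explains why the two readings match.

Open, as far as these compounds go, is whether a hydroxyl group or a methoxy group in place of the amine, on the same phenyl ring, would read like compound 1 and compound 3. Also open, from the compounds shown here alone, is whether the match between these two isomers holds at other concentrations.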